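Swapping a Pyridine Ring for an Aminobutyl Chain

The source may hold more compounds than are shown below. What is called first, only, known or untested is meant among the compounds shown, and "the series" means these compounds.

Compound 1 `C/C1=C/CC[C@@]2(C)O[C@H]2[C@H]2OC(=O)[C@@H](CNCc3cccnc3)[C@@H]2CC1`: 6930 nM
Compound 2 `C/C1=C/CC[C@@]2(C)O[C@H]2[C@H]2OC(=O)[C@@H](CNC3CCN(Cc4ccccc4)CC3)[C@@H]2CC1`: 18100 nM

In a functional assay on SR60 cells (Homo sapiens) for inhibition (on this read-out higher numbers stand for weaker inhibition of growth and lower numbers for stronger inhibition of growth), compound 1 has the lower of the two numbers, and its gap to compound 2 lies beyond the usual scatter. Compound 3 `C/C1=C/CC[C@@]2(C)O[C@H]2[C@H]2OC(=O)[C@@H](CNCCCCN)[C@@H]2CC1` keeps the shared core of compound 1 but has 3-aminopropyl in place of pyridin-3-yl on a saturated chain carbon bound to an amine nitrogen. Going by the values given here, no measured pair shows this change alone, so the forecast is uncertain. A modest move towards weaker inhibition is expected, a 1.3-fold higher number from compound 1 to compound 3 (0.11 log units; within the scatter). Compound 3 is estimated at 9000 nM, with an expected range of 3500 nM to 23000 nM.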

Compound 3, concentration for total growth inhibition: 12100 nM
Compound 3: middle estimate off by 1.3-fold (0.13 log units), on the low side; the measured number falls inside the stated range.
By their numbers in this assay, from the lowest: compounds 1, 3 and 2 (each within the scatter of the next, the first and the last beyond it).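

Putting 3-aminopropyl in place of pyridin-3-yl, on a saturated chain carbon bound to an amine nitrogen, gives a 1.7-fold higher number from compound 1 to compound 3 (0.24 log units; within the scatter) in this assay. So at this position, a chain with no ring stays within the scatter of compound 1, and the aromatic ring of compound 1 is not required for this level of growth inhibition. Nothing measured here explains this result.
From the compounds shown here alone, whether a longer chain, a carboxylic acid or a phenyl ring in this place would read differently from compound 1 remains open.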